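Swapping the dichlorophenyl for an indole in a hydrazone series

The compounds below may be only part of what the source reports. "The series", "measured", "known", "first", "only" and "open" are said of these compounds alone.

Of the compounds shown here, two of a shared core have been measured. Compound 1 `CN(C)CCn1cnnc1-c1cc(Oc2ccc(NC(=O)N/N=C/c3ccc(Cl)cc3Cl)cc2F)ccn1` carries a 2,4-dichlorophenyl on the carbon double-bonded to nitrogen; in a functional assay on U-87MG ATCC cells (Homo sapiens) for cytotoxicity, read by MTT assay, with a stated time of 72 h (on this read-out higher numbers stand for weaker inhibition and lower numbers for stronger inhibition), compound 1 gives 2330 nM. Compound 2 `CN(C)CCn1cnnc1-c1cc(Oc2ccc(NC(=O)N/N=C/c3c(Cl)cccc3Cl)cc2F)ccn1` carries a 2,6-dichlorophenyl on that carbon instead. For compound 2 the result in this assay is only a limit of the assay, > 100000 nM, not a measured number. The step of an at least 42-fold higher number from compound 1 to compound 2 (1.63 log units; beyond the scatter) is therefore large, and the fact that it reaches the limit of > 100000 nM in this assay, at which 1 of the 2 values shown sits, means compound 2 stands at the weak end of what this assay reports.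

Compound 3 `CN(C)CCn1cnnc1-c1cc(Oc2ccc(NC(=O)N/N=C/c3c[nH]c4ccccc34)cc2F)ccn1` has not yet been measured. The change from compound 2 is 1H-indol-3-yl in place of 2,6-dichlorophenyl on a carbon with a double bond to nitrogen. Among the compounds with values here, only one measured step, the one from compound 1 to compound 2, touches this position, and it shows that altering the group on this carbon can move the number far. Compound 3 is expected to return toward a measurable value, a downward step of an at least 12-fold lower number from compound 2 to compound 3 (1.09 log units; beyond the scatter), with wide uncertainty.

Compound 3 is estimated at 8000 nM, plausibly between 800 nM and 80000 nM.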

Compound 3, half-maximal inhibitory concentration: 690 nM
Beside the measured number, compound 3's estimate is 12-fold (1.06 log units) above it, and the stated range ends above it.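

The group on this carbon need not be a dichlorophenyl: the 1H-indol-3-yl, which has no chlorine and brings a hydrogen-bond donor, gives the strongest inhibition of the three compounds in this assay, with a 3.4-fold lower number from compound 1 to compound 3 (0.53 log units; beyond the scatter). That step is modest but beyond the scatter, while the gap to the 2,6-dichlorophenyl is far wider, at an at least 140-fold lower number from compound 2 to compound 3 (2.16 log units; beyond the scatter). This wider step gives only a minimum and not an exact size, since one end of it is a limit of the assay and not a number: the limit of > 100000 nM in this assay, at which 1 of the 3 values shown sits.

The indole differs from the dichlorophenyls in several ways at once, gaining a second ring and a ring nitrogen with its hydrogen while losing both chlorines, and the three compounds cannot show which of these changes matters. Going by these compounds, an indole carrying a methyl group on its ring nitrogen, or a naphthalene with the second ring but no ring nitrogen, would pull these features apart, and whether the order of the three groups holds in other cell lines also remains open.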